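Dichlorophenyl in Place of Phenyl on a Pyrimidinone Core

This account rests on a few compounds, and the source may have more. Where it says the series, first, only, none or still open, it means among the compounds named here.

Measured compounds:
compound 1 `Cc1nc(-c2ccc(Cl)cc2)sc1C(=O)CSc1nc(-c2ccccc2)c(C#N)c(=O)[nH]1`, 88.9%;
compound 2 `COc1ccc(-c2nc(C)c(C(=O)CSc3nc(-c4ccc(Cl)cc4)c(C#N)c(=O)[nH]3)s2)cc1`, 102%;
compound 3 `COc1ccc(-c2nc(C)c(C(=O)CSc3nc(-c4ccc(OC)cc4)c(C#N)c(=O)[nH]3)s2)cc1`, 97%.

These three compounds were tested in a functional assay on U-87MG ATCC cells for antiproliferative activity against U-87 MG (Homo sapiens), read by MTT assay, with a stated time of 48 h, tested at 5 uM; on this read-out higher numbers stand for a weaker effect at the one concentration tested and lower numbers for a stronger effect. Compound 1 gives the lowest of the three numbers, but its gap to compound 3 lies within the usual scatter, and only its gap to compound 2 lies beyond it. Compound 2 and compound 3 differ from each other in one place only, and the step of a number 5 percentage points lower from compound 2 to compound 3 (within the scatter) is small.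

The unmeasured compound 4 `Cc1nc(-c2ccc(Cl)cc2)sc1C(=O)CSc1nc(-c2ccc(Cl)c(Cl)c2)c(C#N)c(=O)[nH]1` differs from compound 1 in one place: 3,4-dichlorophenyl in place of phenyl on an aromatic carbon. For the measured compounds named here, the only measured step at that same position is the swap of methoxy for chloro from compound 2 to compound 3, which stayed within the scatter. Going by the values given here, compounds 2 and 3 also carry a different group on the other aryl ring than compound 1, so no measured step reports exactly the present change. Given the small size of the one related step, the step of a number 1.1 percentage points higher from compound 1 to compound 4 (within the scatter) is expected to stay within the scatter. Compound 4 is therefore estimated at 90% in this assay, with a range from 75% to 105%.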

Compound 4, a percentage reported as activity, at one concentration (the size of the read-out at that concentration, not a potency): 101%
For compound 4 the middle estimate is 11 percentage points below the measured one; the measured number falls inside the stated range.
By their numbers in this assay, from the lowest: compounds 1, 3, 4 and 2 (each within the scatter of the next, the first and the last beyond it).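

In this assay the swap of phenyl for 3,4-dichlorophenyl gives a number 12.1 percentage points higher from compound 1 to compound 4 (beyond the scatter) and so shows that a change at this place, on an aromatic carbon of the shared core next to the ring nitrogen and ortho to a cyano group, can move the number beyond the scatter. For the compounds shown here, the only earlier step at this place, a number 5 percentage points lower from compound 2 to compound 3 (within the scatter), did not show that, and it was measured on compounds with a different group on the other aryl ring, whereas here the entering group adds two chlorine atoms and both groups count no hydrogen-bond donors or acceptors. Nothing measured in this set explains why the number rises with this change.

As far as these compounds go, it remains open whether a phenyl carrying a single chlorine would move the number as far as the two chlorine atoms of compound 4 do, and whether the same swap would give a similar step with a methoxy group on the other aryl ring. Also open, from the compounds shown here alone, is what a phenyl bearing an amine or a carboxylic acid would give at this place, as would a longer alkyl chain in place of the aryl ring.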